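A few compounds are considered here, and "the series" means these few. Any claim that something is new, unique, unknown or untested is made for them only; others in the source may bear on it.

Measured in a functional assay on A2780 cells (Homo sapiens) for inhibition; a higher number here means a weaker inhibitor, a lower number a stronger inhibitor:
- compound 1 `CCNC(=O)c1noc(-c2cc(C(C)C)c(O)cc2O)c1-c1cc(CO)no1`: 5 nM
- compound 2 `CCNC(=O)c1noc(-c2cc(C(C)C)c(O)cc2O)c1-c1cc(C(=O)NC)no1`: 100 nM

Compound 2 holds the higher number of the two. Compound 3 `CCNC(=O)c1noc(-c2cc(C(C)C)c(O)cc2O)c1-c1cn[nH]c1` is still unmeasured. It carries 1H-pyrazol-4-yl in place of 3-(methylcarbamoyl)-1,2-oxazol-5-yl on an aromatic carbon. Going by the values given here, only one measured step bears on this, and only indirectly: a 20-fold higher number from compound 1 to compound 2 (1.30 log units; beyond the scatter), a large step that came with the methylcarbamoyl group now leaving. Among the compounds with values here, no measured step replaces the whole group. In this assay a moderate move to a lower number is therefore expected, and the expected step is a 3.3-fold lower number from compound 2 to compound 3 (0.52 log units; beyond the scatter). The estimate for compound 3 is 30 nM, with an expected range from 6 nM to 150 nM.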

Compound 3, half-maximal inhibitory concentration: 38 nM
Beside the measured number, compound 3's estimate is 1.3-fold (0.10 log units) below it, within the range that was stated.
By their numbers in this assay, from the lowest: compound 1; then compound 3; then compound 2.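

In this assay, exchanging the whole 3-(methylcarbamoyl)-1,2-oxazol-5-yl group for 1H-pyrazol-4-yl gives a 2.6-fold lower number from compound 2 to compound 3 (0.42 log units; beyond the scatter), so this position does not depend on keeping that group. The same exchange made against the 3-(hydroxymethyl)-1,2-oxazol-5-yl group gives a 7.6-fold higher number from compound 1 to compound 3 (0.88 log units; beyond the scatter), which places the 1H-pyrazol-4-yl compound between the two earlier ones. No supporting evidence accounts for either step. As far as these compounds go, it remains open how a methoxymethyl group or an aminomethyl group in place of hydroxymethyl would compare. Also open, from the compounds shown here alone, is how a carboxylic acid there would read in this assay.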